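A few compounds are considered here, and "the series" means these few. Any claim that something is new, unique, unknown or untested is made for them only; others in the source may bear on it.

Measured compounds:
- compound 1 `CC(O)n1cnc2c(N)nc(I)nc21`: > 500000 nM
- compound 2 `CC(=O)OC(C)n1cnc2c(N)nc(I)nc21`: > 500000 nM
- compound 3 `CC(=O)OC(C)n1cnc2c(S)nc(F)nc21`: > 500000 nM

Of the compounds shown here, three have been tested in a functional assay (Homo sapiens) for inhibition; on this read-out lower numbers stand for stronger inhibition and higher numbers for weaker inhibition. Compound 1 `CC(O)n1cnc2c(N)nc(I)nc21` gives > 500000 nM, which is a limit of the assay and not a number. In this assay compound 2 `CC(=O)OC(C)n1cnc2c(N)nc(I)nc21` gives > 500000 nM, again a limit. Compound 3 `CC(=O)OC(C)n1cnc2c(S)nc(F)nc21` gives > 500000 nM in this assay, likewise a limit.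

Compound 2 and compound 1 differ by hydrogen in place of acetyl on an oxygen on a saturated carbon. The step that the two limits leave unreadable from compound 2 to compound 1 cannot be read in size, since both ends sit at the limit; the three values share (the limit of > 500000 nM in this assay, at which 3 of the 3 values shown sit). How the core of compound 3 differs from that of compound 2 is not broken down here.

Compound 4 `CC(O)n1cnc2c(S)nc(F)nc21` has not yet been measured in this assay. It differs from compound 3 by hydrogen in place of acetyl on an oxygen on a saturated carbon, the same change as that from compound 2 to compound 1, at the same place. On the core of compound 2 that change gave no readable step, and compound 3 itself sits at the limit, so the step that the limit leaves unreadable from compound 3 to compound 4 is expected to be small or not measurable. Compound 4 is therefore estimated at 1000000 nM, with a range from 300000 nM to 5000000 nM, and most likely the assay will again report only a limit for compound 4.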

Compound 4, half-maximal inhibitory concentration: > 500000 nM
Compound 4 ended at the assay's limit; the forecaster's own chance of this, stated with the estimate: 85%; the middle value lies beyond the limit too.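

No new step can be read from this result: compound 3 and compound 4 both stand at a limit in this assay and not at a number, so the exchange of acetyl for hydrogen has no readable size, and the same holds for all the compounds shown: the limit of > 500000 nM in this assay, at which 4 of the 4 values shown sit. The compounds shown leave open whether acetyl or hydrogen on this oxygen makes any difference to inhibition on either core.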